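A few compounds are considered here, and "the series" means these few. Any claim that something is new, unique, unknown or untested is made for them only; others in the source may bear on it.

In an ADME assay on Vero cells (Chlorocebus sabaeus) for cytotoxicity, read by MTT assay, with a stated time of 96 h (a higher number here means that more compound is tolerated, a lower number that less compound is tolerated), compound 3 (`CC(=O)c1ccc2c(c1)nc(-c1ccc(Cl)cc1)n2C1CCCCC1`) stands at > 100000 nM as a limit and not a number. Compound 1 (`CC(=O)c1ccc2[nH]c(-c3ccc(C(F)(F)F)cc3)nc2c1`) also bears trifluoromethyl and stands at > 100000 nM as a limit too. Compound 2 (`CC(=O)c1ccc2c(c1)nc(-c1ccccc1)n2C1CCCCC1`) gives 80000 nM as a number. Among the measured compounds shown here, the series so far shows the limit of > 100000 nM in this assay, at which 2 of the 3 values shown sit, as its main feature. Compound 4 (`CC(=O)c1ccc2c(c1)nc(-c1ccc(C(F)(F)F)cc1)n2C1CCCCC1`) has trifluoromethyl in place of chloro on an aromatic carbon, para to a large group (trifluoromethyl in place of chloro on an aromatic carbon). For the measured compounds named here, the only measured step at this place is an at least 1.2-fold higher number from compound 2 to compound 3 (0.09 log units; that floor lies within the scatter) with chloro in place of hydrogen on an aromatic carbon, so no change beyond the scatter is expected in this assay for compound 4. The estimated size of the change is a number no higher from compound 3 to compound 4 (the limit leaves the size open) and lies within the scatter. Compound 4 is expected at 100000 nM with an estimated range of 55000 nM to 180000 nM in all.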

Compound 4, half-maximal cytotoxic concentration: 35000 nM
Estimate against measurement, compound 4: 2.9-fold (0.46 log units) above, outside the stated range (below it).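

In this assay this place proves sensitive to the group it carries: trifluoromethyl in place of chloro gives an at least 2.8-fold lower number from compound 3 to compound 4 (0.45 log units; beyond the scatter) and trifluoromethyl in place of hydrogen gives a 2.3-fold lower number from compound 2 to compound 4 (0.36 log units; beyond the scatter) while the earlier step to chloro stayed within the scatter. Cyclohexyl on the aromatic nitrogen also counts once trifluoromethyl is present, giving an at least 2.8-fold lower number from compound 1 to compound 4 (0.45 log units; beyond the scatter) as a further step beyond the scatter. Steps starting from a limit give only a floor for their size: the limit of > 100000 nM in this assay, at which 2 of the 4 values shown sit.

From the compounds shown here alone, whether an amine or a methoxy group at this place would lower the tolerated concentration further stays open. So does the effect of a methyl group in place of cyclohexyl on the aromatic nitrogen.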